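This account rests on a few compounds, and the source may have more. Where it says the series, first, only, none or still open, it means among the compounds named here.

Of the compounds shown here, three sharing one core have been measured in a functional assay (aorta) with Rattus norvegicus as the target; on this read-out higher numbers stand for higher potency (the scale is a negative logarithm) and lower numbers for lower potency. Compound 1 `CC1(C)C=C(n2ccccc2=O)c2cc(C(=O)c3ccc(O)cc3)ccc2O1` gives 6.65, and compound 2 `CC1(C)C=C(n2ccccc2=O)c2cc(C(=O)c3ccccc3F)ccc2O1` gives 7.08; the two differ by 2-fluorophenyl in place of 4-hydroxyphenyl on a carbonyl carbon, and that change produced a step of a number 0.43 log units higher from compound 1 to compound 2 (beyond the scatter). Compound 3 `CC1(C)C=C(n2ccccc2=O)c2cc(OCC(=O)c3ccc(F)cc3)ccc2O1` gives 4.63, the lowest of the three numbers, and stands well apart from compound 1 and compound 2 in this assay.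

Compound 4 `CC1(C)C=C(n2ccccc2=O)c2cc(OS(=O)(=O)F)ccc2O1` is the next compound to be measured, and it is reached from compound 3 by a single change:

fluorosulfonyl in place of ((4-fluorophenyl)carbonyl)methyl on an oxygen on an aromatic ring

For the measured compounds named here, no measured step bears on this change directly. Going by the values given here, the only measured step is the one from compound 1 to compound 2, which concerns a group on a carbonyl carbon rather than on an aromatic oxygen, and its modest size says little about swapping the larger leaving group for the much smaller entering one. Among the compounds with values here, the only guide is that compound 3, the one carrying this oxygen-linked group, sits far below the other two. With so little to lean on, the step from compound 3 to compound 4 is expected to be a number 0.37 log units higher from compound 3 to compound 4 (beyond the scatter), with wide uncertainty. Compound 4 is therefore estimated at 5, within a range from 4 to 6.2.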

Compound 4, logarithm of the reciprocal of the active concentration, log(1/C): 7.95
Compound 4: the middle estimate sits 2.95 log units below what was measured; the measured number lies above the stated range.
By their numbers in this assay, from the lowest: compound 3; then compound 1; then compound 2; then compound 4.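

Putting fluorosulfonyl in place of ((4-fluorophenyl)carbonyl)methyl on this oxygen gives a number 3.32 log units higher from compound 3 to compound 4 (beyond the scatter) in this assay, so the low number of compound 3 does not hold for every group on an oxygen at this aromatic ring; the entering group has fewer heavy atoms and no ring, which shows that a ring-bearing group on this oxygen is not needed for a high number. The same compound also stands above both compounds that carry an aryl carbonyl group on the aromatic carbon instead, with a number 0.87 log units higher from compound 2 to compound 4 (beyond the scatter) and a number 1.30 log units higher from compound 1 to compound 4 (beyond the scatter), so neither of those carbonyl groups is needed for a high number either. Nothing among the data available explains why this change has so large an effect.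

For the compounds shown here, with only two groups on this oxygen, and those two differing in their ring, their size and their sulfur at once, the part of the change that matters stays open. A methanesulfonyl group on the same oxygen, which keeps the sulfur but lacks the fluorine, and a plain methyl group there would begin to pull those parts apart.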